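Trimming a Ring Substituent with Solubility in View

This account rests on a few compounds, and the source may have more. Where it says the series, first, only, none or still open, it means among the compounds named here.

Three compounds sharing one core have been checked in a physicochemical assay for solubility; on this read-out lower numbers stand for lower solubility and higher numbers for higher solubility. Compound 1, `CNC(=O)c1cc(C(=O)NCCC2CCOCC2)cn(Cc2ccccc2)c1=O`, gives a reading of >= 127 ug/mL, which is a limit of the assay rather than a number. Compound 2, `CNC(=O)c1cc(C(=O)NC2CCC2)cn(Cc2ccccn2)c1=O`, gives >= 103 ug/mL, again only a limit. Compound 3, `CNC(=O)c1cc(C(=O)NC2CC2)cn(Cc2cccc3[nH]c(C)nc23)c1=O`, gives >= 198 ug/mL, also a limit. Going by the values given here, no step between measured compounds can be computed, so compound 1 stands among three readings that all sit at limits, as the limit of >= 127 ug/mL in this assay, at which 1 of the 3 values shown sits, the limit of >= 103 ug/mL in this assay, at which 1 of the 3 values shown sits, and the limit of >= 198 ug/mL in this assay, at which 1 of the 3 values shown sits, show. Compound 4, `CNC(=O)c1cc(C(=O)NCCOC)cn(Cc2ccccc2)c1=O`, differs from compound 1 by methoxy in place of oxan-4-yl on a saturated chain carbon, two bonds along the chain from an amide-type nitrogen. For this change no shift beyond the usual scatter is expected. Compound 4 is estimated at 150 ug/mL, with a range from 80 ug/mL to 300 ug/mL. The expected step that the limit leaves unreadable from compound 1 to compound 4 is thus small, and a limit reading is likely again.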

Compound 4, solubility: >= 164 ug/mL
Compound 4 gave a limit, no number; the forecaster's own chance of this, stated with the estimate: 70%; middle value at least 1.0-fold (0.03 log units) away from the limit.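

Compound 1 and compound 4 both give limits rather than numbers in this assay, and the step between them cannot be read. Going by these compounds, whether methoxy in place of oxan-4-yl shifts this read-out at all remains open.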